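A few compounds are considered here, and "the series" means these few. Any claim that something is new, unique, unknown or untested is made for them only; others in the source may bear on it.

Measured in a toxicity assay on Vero cells (Chlorocebus sabaeus) for cytotoxicity, read by MTT assay; a higher number here means a weaker inhibitor, a lower number a stronger inhibitor:
- compound 1 `COC(=O)NC(=O)c1ccsc1NC(=O)c1ccc(S(=O)(=O)N2CCCCCC2)cc1`: 9.13 ug/mL
- compound 2 `COC(=O)NC(=O)c1ccsc1NC(=O)c1ccc(S(=O)(=O)N2CCC(c3ccccc3)CC2)cc1`: "nd" (no result reported)
- compound 3 `COC(=O)NC(=O)c1ccsc1NC(=O)c1ccc(S(=O)(=O)NC2CCOCC2)cc1`: 35.7 ug/mL

Within the data shown here, compound 2 has no number, so only two values can be compared, and compound 1 holds the lower of them at 9.13 ug/mL. Compound 4 `CCOC(=O)NC(=O)c1ccsc1NC(=O)c1ccc(S(=O)(=O)N2CCCCCC2)cc1` differs from compound 1 by methyl in place of hydrogen on a saturated chain carbon bound to an oxygen next to a carbonyl group, which reads as methoxycarbonyl to ethoxycarbonyl. Among the measured compounds shown here, the only measured step, a 3.9-fold higher number from compound 1 to compound 3 (0.59 log units; beyond the scatter), concerns a group on a sulfonyl sulfur, so it says little about this change. For the measured compounds named here, no measured step covers the methoxycarbonyl group, and therefore no shift beyond the scatter is expected in this assay. The expected step is a 1.1-fold lower number from compound 1 to compound 4 (0.03 log units; within the scatter). Compound 4 is estimated at 8.5 ug/mL, with an expected range from 3.5 ug/mL to 20 ug/mL.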

Compound 4, half-maximal inhibitory concentration: 3.42 ug/mL
Compound 4: the middle estimate sits 2.5-fold (0.40 log units) above what was measured, and the stated range ends above it.
By their numbers in this assay, from the lowest: compound 4; then compound 1; then compound 3.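

Among these compounds, the earlier compounds differed only in the group on the sulfonyl sulfur, so this is the first look at methoxycarbonyl to ethoxycarbonyl, and in this assay the change gives a 2.7-fold lower number from compound 1 to compound 4 (0.43 log units; beyond the scatter). A single methyl, added on a saturated chain carbon bound to an oxygen next to a carbonyl group, thus moves the number beyond the scatter, and downward. No measurement at hand bears on why it moves. From the compounds shown here alone, whether a longer chain such as propoxycarbonyl or a branched isopropoxycarbonyl lowers the number further stays open. So does whether the same step holds with the (oxan-4-yl)amino group of compound 3 on the sulfonyl sulfur.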